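A few compounds are considered here, and "the series" means these few. Any claim that something is new, unique, unknown or untested is made for them only; others in the source may bear on it.

Working notes on the series.

Compound 1 `OC(c1ccc(Cl)cc1)(c1ccc(Br)cc1)c1cncnc1` and compound 2 `OC(c1ccc(Cl)cc1)(c1ccc(Br)cc1)c1cccnc1` share a core; compound 3 `Clc1ccc(C(c2cncnc2)c2ccccc2Cl)cc1` and compound 4 `Clc1ccc(C(c2cccnc2)c2ccccc2Cl)cc1` share another, and the difference between the two cores is not broken down here. In an ADME assay on L6 cells (Rattus norvegicus) for cytotoxicity, read by resazurin assay, with a stated time of 72 h (a lower number here means a stronger inhibitor, a higher number a weaker inhibitor), compound 1 gives 58700 nM. In this assay compound 2 gives 57000 nM. The step of a 1.0-fold lower number from compound 1 to compound 2 (0.01 log units; within the scatter) is the change (pyridin-3-yl in place of pyrimidin-5-yl on a saturated chain carbon bound to two aromatic carbons and an oxygen on a saturated carbon).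

For compound 3 only a limit is known in this assay, namely > 100000 nM; it is one of the values at the limit of > 100000 nM in this assay, at which 1 of the 3 values shown sits. The change to compound 4 is pyridin-3-yl in place of pyrimidin-5-yl on a saturated chain carbon bound to two aromatic carbons. It is the same kind of change as that from compound 1 to compound 2, though the place differs: in the first pair the carbon also carries an oxygen on a saturated carbon, in the second pair it does not.

Because the step of a 1.0-fold lower number from compound 1 to compound 2 (0.01 log units; within the scatter) lay within the scatter, the corresponding step that the limit leaves unreadable from compound 3 to compound 4 is expected to be small as well. Compound 4 is therefore estimated at 150000 nM in this assay, with a range from 80000 nM to 300000 nM, and the assay may again report only a limit.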

Compound 4, half-maximal inhibitory concentration: 62300 nM
Compound 4: the middle estimate sits 2.4-fold (0.38 log units) above what was measured, outside the stated range (below it).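

Putting pyridin-3-yl in place of pyrimidin-5-yl on a saturated chain carbon bound to two aromatic carbons gives an at least 1.6-fold lower number from compound 3 to compound 4 (0.20 log units; that floor lies within the scatter) in this assay, and this figure is a floor and not the size of the step. The data therefore neither show that the change carries unchanged from the core of compound 1 to the core of compound 3 nor show that its size depends on the core: the same change on two cores in this assay, a 1.0-fold lower number (0.01 log units; within the scatter) from compound 1 to compound 2 and an at least 1.6-fold lower number (0.20 log units; that floor lies within the scatter) from compound 3 to compound 4; the limit leaves it open whether they differ. Compound 3 has only a limit of the assay, > 100000 nM.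

The compounds shown leave open what the same change gives on a core in which an amine takes the place of the oxygen on the saturated carbon, or in which a carboxylic acid is attached to the saturated chain carbon. They also leave open how a plain phenyl ring would compare with pyridin-3-yl and pyrimidin-5-yl on that carbon.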